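This account rests on a few compounds, and the source may have more. Where it says the series, first, only, none or still open, it means among the compounds named here.

In an ADME assay on HEL cells (Homo sapiens) for cytotoxicity, read by microscopy (on this read-out lower numbers stand for higher toxicity in this test and higher numbers for lower toxicity in this test), the three measured compounds all sit at the top of the tested range. Compound 1 `N#Cc1ccc(OCCCCCn2ccc(=O)[nH]c2=O)cc1` gives 100000 nM in this assay. Compound 2 `O=c1ccn(CCCCCOc2ccccc2)c(=O)[nH]1` gives only a limit in this assay, > 100000 nM, and not a number. Compound 3 `O=c1ccn(CCCCCOc2ccc(Br)cc2)c(=O)[nH]1` gives 100000 nM in this assay, which puts it level with compound 1, its nearest neighbour on the numbers shown; the step of no change at the digits printed from compound 1 to compound 3 (within the scatter) stays within the scatter. The steps of a number no lower from compound 1 to compound 2 (the limit leaves the size open) and a number no higher from compound 2 to compound 3 (the limit leaves the size open) are each bounded by a limit, so their size cannot be read, and the limit of > 100000 nM in this assay, at which 1 of the 3 values shown sits, marks that one of the three values is such a limit.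

Compound 4 `O=c1ccn(CCCCCOc2ccc(-c3ccccc3)cc2)c(=O)[nH]1` differs from compound 3 by one change: phenyl in place of bromo on an aromatic carbon. Within the data shown here, no measured step swaps in a phenyl group, so only the bromo-for-cyano step of compound 1 to compound 3, which stayed within the scatter, bears on it indirectly. The account therefore expects no step beyond the scatter, a 1.3-fold lower number from compound 3 to compound 4 (0.10 log units; within the scatter), and allows that a limit may again be returned. For compound 4 the estimate in this assay is 80000 nM, with a range from 30000 nM to 100000 nM.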

Compound 4, minimum cytotoxic concentration: 100000 nM
Compound 4: middle estimate off by 1.3-fold (0.10 log units), on the low side; the range from low to high includes it.
By their numbers in this assay, from the lowest: compounds 1, 3 and 4 (each within the scatter of the next).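

In this assay, the exchange of bromo for phenyl gives no change at the digits printed from compound 3 to compound 4 (within the scatter), so at this position, on an aromatic carbon para to a large group, one bromine atom gives way to six carbon atoms and a six-membered aromatic ring without a step beyond the scatter. The larger group also stands level with the nitrile, with phenyl in place of cyano giving no change at the digits printed from compound 1 to compound 4 (within the scatter), which extends to a ring-bearing substituent what the earlier cyano-to-bromo step showed for a single atom. Compound 2 remains a limit and not a number, and the steps that involve it cannot be read, with a number no higher from compound 2 to compound 4 (the limit leaves the size open) as the new one among them: the limit of > 100000 nM in this assay, at which 1 of the 4 values shown sits.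

The compounds shown leave open whether any substituent at this position can bring the number in this assay clearly down, as cyano, bromo and phenyl all give the same printed value. They also leave open what an amine or a carboxylic acid would do in this place, and what a longer chain between the shared core and the aromatic ring would do.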